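The source may hold more compounds than are shown below. What is called first, only, known or untested is meant among the compounds shown, and "the series" means these compounds.

Working notes on the series. Of the compounds shown here, three sharing one core have numbers so far, and no two of them differ in one place only. In a functional assay on OVCAR-8 cells (Homo sapiens) for antiproliferative activity (a lower number here means a stronger inhibitor, a higher number a weaker inhibitor), compound 1 (`Cn1ncc(Cl)c1-c1cc(C(=O)N[C@@H]2CNCC[C@H]2c2ccc(C(F)(F)F)cc2)oc1Cl`) gives 120 nM and compound 3 (`Cn1ncc(Cl)c1-c1cc(C(=O)N[C@@H]2CN[C@H](CCO)C[C@H]2c2ccc(F)c(F)c2)oc1Cl`) gives 460 nM. Compound 2 (`Cn1ncc(Cl)c1-c1cc(C(=O)N[C@@H]2CN[C@H](CCn3cncn3)C[C@H]2c2ccc(Cl)c(Cl)c2)oc1Cl`) gives 1560 nM, the highest of the three numbers and beyond the scatter from both of the others, which makes it the weakest inhibitor of the set.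

Compound 4 (`C=CC[C@@H]1C[C@@H](c2ccc(Cl)c(Cl)c2)[C@H](NC(=O)c2cc(-c3c(Cl)cnn3C)c(Cl)o2)CN1`) has not yet been measured in this assay. Relative to compound 2, the change is vinyl in place of (1H-1,2,4-triazol-1-yl)methyl on a saturated chain carbon bound to a saturated ring carbon. Cut one bond further out, this reads as 2-(1H-1,2,4-triazol-1-yl)ethyl to allyl.

Among the measured compounds shown here, no measured pair shows this change directly, so the expectation is weakly founded. Compound 2 at 1560 nM sits at the top of the measured range, so a move toward the lower numbers of compound 3 and compound 1 is the more likely direction. The expected step of a 2.4-fold lower number from compound 2 to compound 4 (0.38 log units; beyond the scatter) is moderate and toward a lower number, with little change still possible. Compound 4 is estimated at 650 nM, with an expected range from 230 nM to 1900 nM.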

Compound 4, half-maximal inhibitory concentration: 990 nM
For compound 4 the middle estimate is 1.5-fold (0.18 log units) below the measured one; the range from low to high includes it.
By their numbers in this assay, from the lowest: compound 1; then compound 3; then compounds 4 and 2 (each within the scatter of the next).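

Among the compounds shown here, this is the first one-place comparison, and it concerns the group on a saturated chain carbon bound to a saturated ring carbon: in this assay, vinyl in place of (1H-1,2,4-triazol-1-yl)methyl gives a 1.6-fold lower number from compound 2 to compound 4 (0.20 log units; within the scatter). The exchange removes a five-membered aromatic ring with 3 hetero atoms and 3 hydrogen-bond acceptors, and takes the group from 6 heavy atoms to 2, yet the two numbers stay within the scatter of each other, so the triazole is not needed here to hold activity at this level. Nothing available explains this outcome, and no supporting data bear on it.

Going by these compounds, whether any group at this place can shift the number beyond the scatter remains open, for instance a primary amine, a carboxylic acid or a longer alkyl chain in place of the allyl. Compound 1 and compound 3 each differ from compound 4 in more than one place, so their lower numbers cannot be read as an effect of this chain alone.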